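Methylamino on the sulfonyl: what the cytotoxicity limits allow

The compounds below may be only part of what the source reports. "The series", "measured", "known", "first", "only" and "open" are said of these compounds alone.

The measured compounds, each with its result in an ADME assay on HEp-2 cells (Homo sapiens) for cytotoxicity, with a stated time of 4 days; a lower number here means that less compound is tolerated, a higher number that more compound is tolerated:

Compound 1, `CS(=O)(=O)CCn1c(Cn2cc(S(C)(=O)=O)c3ccccc32)nc2ccccc21`, gives > 100000 nM, which is a limit of this assay and not a number.
Compound 2, `CS(=O)(=O)CCn1c(Cn2cc(S(C)(=O)=O)c3ccccc32)nc2cc(Cl)ccc21`, gives > 100000 nM, again a limit of this assay.
Compound 3, `CS(=O)(=O)CCCn1c(Cn2cc(S(C)(=O)=O)c3ccccc32)nc2cc(Cl)ccc21`, gives > 100000 nM, also a limit of this assay.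

Compound 3 therefore stands where the other two stand: at the limit, with no number below it. Among the measured compounds shown here, the two steps among the measured compounds, a step that the two limits leave unreadable from compound 1 to compound 2 and a step that the two limits leave unreadable from compound 2 to compound 3, cannot be sized, since both ends sit at the limit; the only evidence is the limit of > 100000 nM in this assay, at which 3 of the 3 values shown sit.

Compound 4, `CNS(=O)(=O)c1cn(Cc2nc3cc(Cl)ccc3n2CCCS(C)(=O)=O)c2ccccc12`, differs from compound 3 by methylamino in place of methyl on a sulfonyl sulfur. For the measured compounds named here, no measured step touches the sulfonyl sulfur on the indole part of the core, so nothing among the three compounds bears directly on this change, and what they offer is that every value so far sits at the limit.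

On that basis compound 3 to compound 4 is expected to show a number no higher from compound 3 to compound 4 (the limit leaves the size open), that is, no step beyond the scatter. Compound 4 is accordingly estimated at 100000 nM in this assay, within a range of 50000 nM to 300000 nM, most likely reported again as a limit.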

Compound 4, half-maximal cytotoxic concentration: > 100000 nM
Compound 4: only a limit was reported (the forecaster's own chance of this, stated with the estimate: 85%); the middle value lies on the limit itself.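

Compound 3 and compound 4 both stand at a limit in this assay and not at a number, so no new step can be read between them: the limit of > 100000 nM in this assay, at which 4 of the 4 values shown sit.

The compounds shown leave open how much of any of them is actually tolerated, and whether methylamino in place of methyl on the sulfonyl sulfur changes that at all.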